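Amide aryl swap in the dimethoxy series: compound 3

The source may report more compounds than this note shows. Statements on the series, on what has been measured and on what is new or still open speak of the compounds shown alone.

Working notes on the amide series.

Of the compounds shown here, two carry numbers so far. Compound 1 `COc1cc2c(cc1OC)C(CC(=O)Nc1ccc(Br)cc1)CC2` in a functional assay on the whole organism (strain Wistar) for inhibition, with Rattus norvegicus as the target, read by paw edema, with a stated time of 3 h, at a dose of 100 mg/kg (a lower number here means less inhibition, a higher number more inhibition at the dose given (going by the name of the read-out)), gives 43.5%. Compound 2 `COc1ccccc1NC(=O)CC1CCc2cc(OC)c(OC)cc21` in this assay gives 21.7%. Compound 2 stands lowest of the two numbers; its nearest neighbour is compound 1, and the change of aryl group on the amide nitrogen gave a number 21.8 percentage points lower from compound 1 to compound 2 (beyond the scatter).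

The next compound, compound 3 `COc1cc2c(cc1OC)C(CC(=O)Nc1cccnc1)CC2`, differs from compound 2 by pyridin-3-yl in place of 2-methoxyphenyl on an amide-type nitrogen.

Among the compounds with values here, only one measured step bears on this change, the one from compound 1 to compound 2, and it is a different exchange on the same amide nitrogen: it shows that the aryl group at that position shifts the read-out in this assay by a modest amount beyond the scatter, but it gives no direction for pyridin-3-yl, which has no measured neighbour here. The expectation for compound 3 is therefore a step of uncertain sign and modest size, with the wide range reflecting that.

Compound 3 is expected to give 30% in this assay, within 12% to 50%.

That estimate means an expected step of a number 8.3 percentage points higher from compound 2 to compound 3 (within the scatter) in this assay.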

Compound 3, a percentage reported as inhibition, in the whole organism at one dose (the size of the read-out at that dose, not a potency): 33.3%
Estimate against measurement, compound 3: 3.3 percentage points below, and the stated range covers the measured number.
By their numbers in this assay, from the lowest: compound 2; then compound 3; then compound 1.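

In this assay, pyridin-3-yl in place of 2-methoxyphenyl on the amide-type nitrogen gives a number 11.6 percentage points higher from compound 2 to compound 3 (beyond the scatter) and so shows that this position can carry an aromatic ring with a hetero atom while retaining a read-out above that of the 2-methoxyphenyl amide. Set against the other aryl group, pyridin-3-yl in place of 4-bromophenyl gives a number 10.2 percentage points lower from compound 1 to compound 3 (beyond the scatter), which places compound 3 between the other two and makes compound 1 the highest of the three, with every step among them beyond the scatter. No accompanying measurement bears on this order of the three groups.

The three aryl groups differ in ring type and in substituent together, so an unsubstituted phenyl on the same nitrogen would be needed to separate the contribution of the bromine and methoxy substituents from that of the ring itself. Also open, as far as these compounds go, is how the read-out responds to groups of another kind at this place, such as a phenyl bearing a carboxylic acid, a saturated ring amine such as piperidin-4-yl, or a longer alkyl chain.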